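The compounds below may be only part of what the source reports. "The series", "measured", "known", "first", "only" and "open" are said of these compounds alone.

Measured compounds in an ADME assay on Colon (Mus musculus, strain C57BL/6) for metabolic stability, read by HPLC, with a stated time of 12 h; a higher number here means that the compound lasts longer, a lower number that the compound disappears faster:
compound 1, `O=C(O)[C@H](CO)NC(=O)[C@H]1C[C@H](O)CN1` — compound 1 gives > 12 h, which is a limit of this assay rather than a number.
compound 2, `O=C(N[C@H](CO)C(=O)O)[C@@H]1C[C@@H](O)CN1` — compound 2 gives > 12 h, again a limit and not a number.

Compound 1 therefore stands at the limit of this assay, and it is not alone there, since (the limit of > 12 h in this assay, at which 2 of the 2 values shown sit). Among the compounds with values here, the only measured step, a step that the two limits leave unreadable from compound 1 to compound 2, cannot be read, because both ends sit at the limit; its structural content is the fact that compounds 1 and 2 differ only in the configuration as drawn.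

Compound 3, `O=C(O)[C@H](CO)NC(=O)[C@@H]1C[C@@H](O)CN1`, differs from compound 1 as follows: the two compounds have the same atoms and bonds and differ only in configuration as drawn: 2 of 3 stereo elements differ; a stereocentre at a saturated ring carbon is drawn R in compound 1 and S in compound 3; a stereocentre at a saturated ring carbon is drawn S in compound 1 and R in compound 3. Within the data shown here, the measured step bearing on this change is the one from compound 1 to compound 2, and it gives no size. No step beyond the scatter is expected here, so the expected step from compound 1 to compound 3 is a number no higher from compound 1 to compound 3 (the limit leaves the size open). Compound 3 is estimated to give 12 h in this assay, within 6 h to 24 h.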

Compound 3, half-life: > 12 h
Compound 3 ended at the assay's limit (the forecaster's own chance of this, stated with the estimate: 70%); the middle value lies on the limit itself.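

In this assay compound 3 gives > 12 h, which is a limit and not a number. Within the data shown here, with compound 1, compound 2 and compound 3 all at this limit, no step among them can be read. Whether configuration alters the half-life at all remains open: the limit of > 12 h in this assay, at which 3 of the 3 values shown sit.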